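The compounds below may be only part of what the source reports. "The series", "measured", "known", "first", "only" and "open" are said of these compounds alone.

Working notes on the series. Going by the values given here, compound 1 `N#C/C(=C\c1ccc[nH]1)C(=O)NCc1ccc(Cl)c(Cl)c1` and compound 2 `COc1ccc(CNC(=O)/C(C#N)=C/c2ccc3ccccc3c2)cc1` are the two measured members. In a functional assay on HT-29 cells (Homo sapiens) for inhibition, read by MTT assay, with a stated time of 72 h (on this read-out higher numbers stand for weaker inhibition of growth and lower numbers for stronger inhibition of growth), compound 1 gives 85000 nM, and in this assay compound 2 gives 54000 nM. Compound 1 has the highest of the two numbers; the nearest is compound 2, whose number is within the scatter of compound 1, so no order between them can be drawn. Among the compounds with values here, the pair differs in more than one place, and no step between them is counted.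

Compound 3 `N#C/C(=C\c1ccc(Cl)cc1)C(=O)NCc1ccc(Cl)c(Cl)c1` has not been measured in this assay. It differs from compound 1 by 4-chlorophenyl in place of 1H-pyrrol-2-yl on a double-bonded chain carbon bound to a double-bonded chain carbon. Within the data shown here, no measured step covers this exchange, so the expectation rests on compound 1 alone: the step from compound 1 to compound 3 in this assay is expected to be none beyond the scatter, estimated as a 1.4-fold lower number from compound 1 to compound 3 (0.15 log units; within the scatter). Compound 3 is therefore expected to give about 60000 nM in this assay, within a range of 20000 nM to 150000 nM.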

Compound 3, concentration for 50% growth inhibition: 33000 nM
Estimate against measurement, compound 3: 1.8-fold (0.26 log units) above; the measured number falls inside the stated range.
By their numbers in this assay, from the lowest: compounds 3, 2 and 1 (each within the scatter of the next, the first and the last beyond it).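

Going by these compounds alone, the exchange on a double-bonded chain carbon bound to a double-bonded chain carbon gives the first readable step in this assay (a 2.6-fold lower number from compound 1 to compound 3 (0.41 log units; beyond the scatter)), modest in size, and it shows that this position responds to the group placed there. Here, 4-chlorophenyl, with no hydrogen-bond donor, goes with the lower number, so the donor counted on 1H-pyrrol-2-yl is not required for growth inhibition at this level in this pair. No measurement on hand bears on why the number moves.

The exchange alters ring size, hetero atom, donor count and chlorine together, and this single step cannot separate them. As far as these compounds go, whether plain phenyl, 4-methoxyphenyl or a phenyl ring carrying a carboxylic acid or an amine would extend the step stays open, as does the effect of the chlorine alone.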